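E-to-Z Switch in a Weakly Active Series

The source may hold more compounds than are shown below. What is called first, only, known or untested is meant among the compounds shown, and "the series" means these compounds.

Three compounds share one core and differ in the ring at one end and in the geometry of the double bond joining the two rings. Compound 1 `CCNC(=O)Nc1ccc(/C=C\c2cc(OC)c(OC)c(OC)c2)cc1` carries three methoxy groups on that ring and is drawn with a Z double bond. Compound 2 `CCNC(=O)Nc1ccc(/C=C/c2cccc(Cl)c2)cc1` has a chloro group there, and compound 3 `CCNC(=O)Nc1ccc(/C=C/c2cc(C)cc(C)c2)cc1` two methyl groups; both are drawn E.

In a functional assay on MCF7 cells (Homo sapiens) for inhibition, read by sulforhodamine B assay, with a stated time of 48 h (a higher number here means a weaker inhibitor, a lower number a stronger inhibitor), compound 1 gives 21000 nM, compound 2 gives 20000 nM and compound 3 gives 20000 nM. All three numbers sit within the scatter of one another, so none of these compounds can be called stronger or weaker than another. Every one of them is a weak inhibitor of cell growth.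

Compound 4 `CCNC(=O)Nc1ccc(/C=C\c2cc(C)cc(C)c2)cc1` is the next step from compound 3. The change is the two compounds have the same atoms and bonds and differ only in configuration as drawn: 1 of 1 stereo elements differ; a double bond is drawn E in compound 3 and Z in compound 4. Going by the values given here, no measured pair in this set shows what such a switch alone does. Among the compounds with values here, the only Z compound measured, compound 1, gives 21000 nM, a number within the scatter of compound 3. An estimate for compound 4 is therefore a step of a 1.1-fold lower number from compound 3 to compound 4 (0.05 log units; within the scatter), with no change beyond the scatter expected. Compound 4 is expected to give about 18000 nM, within the range 5000 nM to 50000 nM.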

Compound 4, half-maximal inhibitory concentration: 17000 nM
Beside the measured number, compound 4's estimate is 1.1-fold (0.02 log units) above it, within the range that was stated.
By their numbers in this assay, from the lowest: compounds 4, 2, 3 and 1 (each within the scatter of the next).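

Going by these compounds alone, compound 3 and compound 4 are the first pair in this set to test the double bond on its own, with nothing else in the structure altered: the fact that compounds 3 and 4 differ only in the configuration as drawn. In this assay, the switch from E to Z gives a 1.2-fold lower number from compound 3 to compound 4 (0.07 log units; within the scatter), so with two methyl groups on the ring, the drawn geometry makes no difference that can be told apart from the scatter. Within the data shown here, the earlier compounds could not show this, as the one Z compound among them, compound 1, differs from compound 2 and compound 3 in its ring groups as well as in its geometry, so its number could not be tied to the double bond alone.

As far as these compounds go, whether the geometry matters as little with other ring groups stays open, since a single pair speaks only for the two methyl groups and not for the chloro group of compound 2 or the three methoxy groups of compound 1. Also open, from the compounds shown here alone, is whether a different group on that ring, such as an amine or a carboxylic acid, would move the number away from this weak level at all.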